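Replacing a methyl with a phenyl on compound 2

A few compounds are considered here, and "the series" means these few. Any claim that something is new, unique, unknown or untested is made for them only; others in the source may bear on it.

Compound 1 `CC/C=C\C[C@H]1C(=O)C=C[C@H]1CC(=O)OCCCCC` - 37 uM
Compound 2 `CC/C=C\C[C@H]1C(=O)C=C[C@H]1CC(=O)OC(C)C` - 58 uM

Going by the values given here, in an ADME assay on RAW264.7 cells (Mus musculus) for cytotoxicity, read by MTT assay, with a stated time of 24 h (a lower number here means that less compound is tolerated, a higher number that more compound is tolerated), the two measured compounds stand level, with compound 2 inside the scatter of its only neighbour. Compound 3 `CC/C=C\C[C@H]1C(=O)C=C[C@H]1CC(=O)OC(C)c1ccccc1` has phenyl in place of methyl on a saturated chain carbon (phenyl in place of methyl on a saturated chain carbon bound to an oxygen next to a carbonyl group and a saturated chain carbon). Among the compounds with values here, one measured step bears on this, as it also altered the group on that side of the ester: a 1.6-fold higher number from compound 1 to compound 2 (0.20 log units; within the scatter), within the scatter. That is weak evidence, and no step beyond the scatter is expected in this assay. The expected step, a 1.3-fold lower number from compound 2 to compound 3 (0.11 log units; within the scatter), stays within the scatter. Compound 3 is estimated at 45 uM, with an expected range of 20 uM to 100 uM.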

Compound 3, half-maximal toxic concentration: 31 uM
Beside the measured number, compound 3's estimate is 1.5-fold (0.16 log units) above it; the range from low to high includes it.
By their numbers in this assay, from the lowest: compounds 3, 1 and 2 (each within the scatter of the next).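

In this assay, a phenyl in place of methyl on this saturated chain carbon gives a 1.9-fold lower number from compound 2 to compound 3 (0.27 log units; within the scatter) and so adds an aromatic ring without a step beyond the scatter. Earlier, only saturated chains had been compared on this side of the ester, and this result extends the comparison to a much larger ring-bearing group. Nothing measured here accounts for the size of this step.

As far as these compounds go, whether an amine or a carboxylic acid at this carbon would also stay within the scatter remains open. So does the outcome for a pyridine ring in place of the phenyl.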